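Diethylamino for methoxy on the benzyl ring of compound 3

A few compounds are considered here, and "the series" means these few. Any claim that something is new, unique, unknown or untested is made for them only; others in the source may bear on it.

Measured compounds:
Compound 1 `CCN1CCN(CCCn2cnc3c(N4CCN(CC)CC4)nc(NCc4ccc(F)cc4)nc32)CC1`: 470 nM
Compound 2 `CCN1CCN(CCCn2cnc3c(N4CCN(C5CCCC5)CC4)nc(NCc4ccc(N(CC)CC)cc4)nc32)CC1`: 150 nM
Compound 3 `CCN1CCN(CCCn2cnc3c(N4CCN(CC)CC4)nc(NCc4ccc(OC)cc4)nc32)CC1`: 200 nM

In an assay on HEK293 cells for antagonist activity at Toll-like receptor 9 (Homo sapiens), read by spectrophotometry (on this read-out lower numbers stand for stronger inhibition and higher numbers for weaker inhibition), compound 3 stands second highest of the three numbers. Its nearest neighbour is compound 2, whose number is lower by a margin within the scatter; its furthest is compound 1, and the step of a 2.4-fold lower number from compound 1 to compound 3 (0.37 log units; beyond the scatter) is modest but beyond the scatter. Compound 4 `CCN1CCN(CCCn2cnc3c(N4CCN(CC)CC4)nc(NCc4ccc(N(CC)CC)cc4)nc32)CC1` has not yet been measured. The change from compound 3 to compound 4 is diethylamino in place of methoxy on an aromatic carbon. Going by the values given here, no measured step covers this exact change. Among the compounds with values here, the one step recorded, a 2.4-fold lower number from compound 1 to compound 3 (0.37 log units; beyond the scatter), concerns a different pair of groups at the same place. Compound 2 carries the diethylamino group but also differs from compound 3 at the piperazine nitrogen, so only its two values can be compared with those of compound 3, and they lie within the scatter of each other. Compound 4 is therefore expected to show a step of a 1.3-fold lower number from compound 3 to compound 4 (0.10 log units; within the scatter) of no clear size beyond the scatter in this assay. The estimate for compound 4 is 160 nM, with a range from 70 nM to 350 nM.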

Compound 4, half-maximal inhibitory concentration: 440 nM
Beside the measured number, compound 4's estimate is 2.8-fold (0.44 log units) below it, outside the stated range (above it).
By their numbers in this assay, from the lowest: compounds 2 and 3 (each within the scatter of the next); then compounds 4 and 1 (each within the scatter of the next).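

In this assay, with ethyl held on the amine nitrogen in a ring, the change on the aromatic carbon gives a 2.2-fold higher number from compound 3 to compound 4 (0.34 log units; beyond the scatter), while a 1.1-fold lower number from compound 1 to compound 4 (0.03 log units; within the scatter) leaves diethylamino and fluoro within the scatter of each other. Among these three groups at this place, methoxy alone gives the lower number. With diethylamino held on the aromatic ring, the other change gives a 2.9-fold higher number from compound 2 to compound 4 (0.47 log units; beyond the scatter), so the low number of compound 2 goes with its cyclopentyl group and not with diethylamino alone. No evidence at hand explains these steps.

The compounds shown leave open how an ethoxy or a dimethylamino group would read at this place. They also leave open whether methoxy would keep its lower number with cyclopentyl on the amine nitrogen.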